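A few compounds are considered here, and "the series" means these few. Any claim that something is new, unique, unknown or untested is made for them only; others in the source may bear on it.

Measured so far:
- Compound 1, `Cn1ccnc1-c1nc(-c2ccccc2)cc(=O)[nH]1`: 4000 nM
- Compound 2, `CCNc1cc(C)nn1-c1nc(C(F)(F)F)cc(=O)[nH]1`: 8000 nM

Both numbers come from an ADME assay on CHO cells (Cricetulus griseus) for cytotoxicity, read by MTT assay; on this read-out lower numbers stand for stronger inhibition and higher numbers for weaker inhibition. In this assay compound 2 gives 8000 nM, and compound 1 gives 4000 nM; the two numbers sit within the usual scatter of one another, so neither compound can be called the more toxic of the pair.

Compound 3, `Cc1cc(Nc2ccccn2)n(-c2nc(C(F)(F)F)cc(=O)[nH]2)n1`, has not yet been measured in this assay. It differs from compound 2 in one place: pyridin-2-yl in place of ethyl on a nitrogen on an aromatic ring. For the measured compounds named here, no measured pair in this set shows what such a change does, so the expectation rests only on compound 2 itself. Compound 3 is expected to give 6000 nM, with a range from 2000 nM to 20000 nM. The expected step of a 1.3-fold lower number from compound 2 to compound 3 (0.12 log units; within the scatter) is one that stays within the usual scatter, in either direction, because compound 2 gives 8000 nM and nothing here points to a larger move.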

Compound 3, half-maximal inhibitory concentration: 23000 nM
Estimate against measurement, compound 3: 3.8-fold (0.58 log units) below; measured number outside the range, above it.
By their numbers in this assay, from the lowest: compounds 1 and 2 (each within the scatter of the next); then compound 3.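

Replacing ethyl with pyridin-2-yl on this nitrogen gives a 2.9-fold higher number from compound 2 to compound 3 (0.46 log units; beyond the scatter) in this assay, a modest change but one that lies beyond the usual scatter. Here, a higher number means weaker inhibition, so this position can affect the cell read-out, and the change from ethylamino to (pyridin-2-yl)amino moves it towards weaker inhibition. No measured evidence here accounts for the step.

With only this one step at the position, the compounds shown leave open whether the result depends on the ring, on its nitrogen or on the larger group as a whole. They also leave open how a cyclohexyl ring or a butyl chain on the same nitrogen would read in this assay.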